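Swapping Methyl for Chloro on a Benzylamide Side Chain

The source may report more compounds than this note shows. Statements on the series, on what has been measured and on what is new or still open speak of the compounds shown alone.

Of the compounds shown here, three sharing a common core have been tested in an assay on microsomes from liver for inhibition of 3-hydroxy-3-methylglutaryl-coenzyme A reductase (Rattus norvegicus); on this read-out lower numbers stand for stronger inhibition and higher numbers for weaker inhibition. Compound 1 `CC(C)c1c(C(=O)N(C)Cc2ccccc2)nn(-c2ccc(F)cc2)c1CC[C@@H](O)C[C@@H](O)CC(=O)O` gives 6.2 nM. Within the data shown here, compound 2 `CC(C)c1c(C(=O)N2CCC[C@H](c3ccccc3)C2)nn(-c2ccc(F)cc2)c1CC[C@@H](O)C[C@@H](O)CC(=O)O` gives 2.1 nM, and the single change between them, a 3.0-fold lower number from compound 1 to compound 2 (0.47 log units; beyond the scatter), is the only step measured so far. Compound 3 `Cc1ccccc1CNC(=O)c1nn(-c2ccc(F)cc2)c(OC[C@@H](O)C[C@@H](O)CC(=O)O)c1C(C)C` gives 17 nM, the highest of the three numbers; it sits nearest to compound 1 and furthest from compound 2, both gaps lying beyond the scatter.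

Compound 4 `CC(C)c1c(C(=O)NCc2ccccc2Cl)nn(-c2ccc(F)cc2)c1OC[C@@H](O)C[C@@H](O)CC(=O)O` is the next to be measured. It differs from compound 3 in one place: chloro in place of methyl on an aromatic carbon. The change sits on the benzyl group of the amide, ortho to a large group, and touches neither the core nor the chain carrying the acid.

Among the measured compounds shown here, no measured step bears directly on this change. For the measured compounds named here, the one step available, a 3.0-fold lower number from compound 1 to compound 2 (0.47 log units; beyond the scatter), alters the whole amine part of the amide rather than a single substituent on its ring, so it offers no guide to swapping methyl for chloro. With nothing in the data to point either way, compound 4 is expected to stay close to compound 3, with any step a 1.1-fold lower number from compound 3 to compound 4 (0.05 log units; within the scatter) likely within the scatter. On that basis the value estimated for compound 4 in this assay is 15 nM, with a range from 6 nM to 40 nM.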

Compound 4, half-maximal inhibitory concentration: 9.5 nM
Compound 4: the middle estimate sits 1.6-fold (0.20 log units) above what was measured; the measured number falls inside the stated range.
By their numbers in this assay, from the lowest: compound 2; then compounds 1, 4 and 3 (each within the scatter of the next, the first and the last beyond it).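

Among these compounds, this is the first step in the set that changes a single substituent on the benzyl ring of the amide, whereas the earlier step replaced the whole amine part. In this assay, chloro in place of methyl on this aromatic carbon, ortho to a large group, gives a 1.8-fold lower number from compound 3 to compound 4 (0.25 log units; within the scatter) and so leaves the two compounds indistinguishable on this read-out. Among the compounds shown here, at this place, then, 2-chlorobenzyl and 2-methylbenzyl serve equally well in this assay, although this single pair shows only that these two groups match and says nothing about why, as no supporting evidence on the cause is available.

Going by these compounds, whether the same holds for other groups at this place, such as fluoro, methoxy, trifluoromethyl or a plain hydrogen, remains open, and a larger group such as a phenyl could read quite differently. Also open, on these data alone, is whether the swap from 2-methylbenzyl to 2-chlorobenzyl would read the same on a compound carrying the chain of compound 1 in place of the chain shared by compound 3 and compound 4.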